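The compounds below may be only part of what the source reports. "The series", "measured", "known", "first", "only" and "open" are said of these compounds alone.

Of the compounds shown here, three built on one shared core have been measured in a functional assay on HeLa cells (Homo sapiens) for inhibition, read by CCK-8 assay, with a stated time of 48 h; on this read-out lower numbers stand for stronger inhibition and higher numbers for weaker inhibition. Compound 1 `COc1ccc(-c2cc3nccc(-c4cc(OC)c(OC)c(OC)c4)n3n2)cc1N` gives 283 nM, the highest of the three numbers; compound 2 `COc1cc(-c2ccnc3cc(-c4ccc5cc[nH]c5c4)nn23)cc(OC)c1OC` gives 125 nM, and compound 3 `COc1cc(-c2ccnc3cc(-c4c[nH]c5ccccc45)nn23)cc(OC)c1OC` gives 195 nM. Among the steps between them, one is a 2.3-fold lower number from compound 1 to compound 2 (0.35 log units; beyond the scatter), while the others are a 1.5-fold lower number from compound 1 to compound 3 (0.16 log units; within the scatter) and a 1.6-fold higher number from compound 2 to compound 3 (0.19 log units; within the scatter).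

Compound 4 `COc1cc(-c2ccnc3cc(-c4ccc5ccn(C)c5c4)nn23)cc(OC)c1OC` has not yet been measured. It differs from compound 1 by 1-methyl-1H-indol-6-yl in place of 3-amino-4-methoxyphenyl on an aromatic carbon. The 1-methyl-1H-indol-6-yl group of compound 4 closely resembles the 1H-indol-6-yl group of compound 2, so the most relevant guide is the step of a 2.3-fold lower number from compound 1 to compound 2 (0.35 log units; beyond the scatter). A similar, modest lowering of the number is therefore expected: a 1.9-fold lower number from compound 1 to compound 4 (0.28 log units; within the scatter). Compound 4 is estimated at 150 nM, with a range from 60 nM to 400 nM.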

Compound 4, half-maximal inhibitory concentration: 187 nM
Compound 4: middle estimate off by 1.2-fold (0.10 log units), on the low side; measured number inside the range.
By their numbers in this assay, from the lowest: compounds 2, 4, 3 and 1 (each within the scatter of the next, the first and the last beyond it).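

In this assay, methyl in place of hydrogen on the indole nitrogen leaves the number within the scatter (a 1.5-fold higher number from compound 2 to compound 4 (0.17 log units; within the scatter)), so at this position the entering group, with no hydrogen-bond donors, gives a number close to that of its parent. Compound 4 also lies within the scatter of the other two compounds (a 1.5-fold lower number from compound 1 to compound 4 (0.18 log units; within the scatter); a 1.0-fold lower number from compound 3 to compound 4 (0.02 log units; within the scatter)). No measured evidence here offers an explanation.

Going by these compounds, whether an ethyl group, or a longer chain ending in an amine, on that nitrogen would keep the number in this range remains open. So does the effect of the same methyl on the 1H-indol-3-yl group of compound 3.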